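From Methoxy to Chloro: Estimating Compound 4

The source may hold more compounds than are shown below. What is called first, only, known or untested is meant among the compounds shown, and "the series" means these compounds.

Of the compounds shown here, three sharing one core have been tested in a functional assay on U-87MG ATCC cells for antiproliferative activity against U-87 MG (Homo sapiens), read by MTT assay, with a stated time of 48 h, tested at 5 uM; on this read-out higher numbers stand for a weaker effect at the one concentration tested and lower numbers for a stronger effect. Compound 1 `COc1ccc(-c2nc(SCC(=O)c3sc(-c4ccccc4)nc3C)[nH]c(=O)c2C#N)cc1` gives 97.3%, the highest of the three numbers. Going by the values given here, compound 3 `COc1ccc(-c2nc(SCC(=O)c3sc(-c4ccc(Cl)cc4)nc3C)[nH]c(=O)c2C#N)cc1` gives 92.1%, and the single measured step between them, a number 5.2 percentage points lower from compound 1 to compound 3 (within the scatter), stays within the scatter. Compound 2 `COc1ccc(-c2nc(C)c(C(=O)CSc3nc(N)c(C#N)c(-c4ccccc4)n3)s2)cc1`, built from the same pieces joined in a different arrangement, gives 61.8%, a number that lies beyond the scatter below compound 1.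

Compound 4 `Cc1nc(-c2ccccc2)sc1C(=O)CSc1nc(-c2ccc(Cl)cc2)c(C#N)c(=O)[nH]1` has not yet been measured. It differs from compound 1 in one place: chloro in place of methoxy on an aromatic carbon. Among the compounds with values here, no measured step covers exactly this exchange. The closest guide is the step from compound 1 to compound 3, which also introduced a chloro on an aromatic carbon and stayed within the scatter. On that basis, no step beyond the scatter is expected in this assay for compound 4. The expected step is a number 5.3 percentage points lower from compound 1 to compound 4 (within the scatter). Compound 4 is therefore estimated to give 92%, within a range from 78% to 102%.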

Compound 4, a percentage reported as activity, at one concentration (the size of the read-out at that concentration, not a potency): 90.9%
Beside the measured number, compound 4's estimate is 1.1 percentage points above it; measured number inside the range.
By their numbers in this assay, from the lowest: compound 2; then compounds 4, 3 and 1 (each within the scatter of the next).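

In this assay the change from 4-methoxyphenyl to 4-chlorophenyl gives a number 6.4 percentage points lower from compound 1 to compound 4 (within the scatter) and so stays within the scatter, which means that on this core this position can lose the methoxy group without a clear change in the read-out. Compound 1 and compound 3 both carry the methoxy group on this ring, so neither could show what happens when it is replaced; the chloro of compound 3 sits on a different ring. Nothing measured here explains the result, as no supporting evidence on either group is available.

As far as these compounds go, whether this position would accept a quite different group, such as an amine or a carboxylic acid, remains open. Also open, from the compounds shown here alone, is whether the same exchange would read alike on the different arrangement of compound 2.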